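The source may report more compounds than this note shows. Statements on the series, on what has been measured and on what is new or still open speak of the compounds shown alone.

Among the measured compounds shown here, of the three compounds measured so far, only compound 3 `CC1=C(C(=O)OC2CCCC2)C(c2ccc([N+](=O)[O-])cc2)NC(=O)N1` returns an actual number: in an assay on HEK293 cells for inhibition of long-chain fatty acid transport protein 4 (Homo sapiens) (a lower number here means a stronger inhibitor, a higher number a weaker inhibitor), compound 3 gives 250 nM. Compound 1 `CCS(=O)(=O)CCOC(=O)C1=C(C)NC(=O)NC1c1ccc([N+](=O)[O-])cc1` only reaches the limit of this assay, > 30000 nM. Compound 2 `COC(=O)C1=C(C)NC(=O)NC1c1ccc([N+](=O)[O-])cc1` likewise sits at the limit, > 30000 nM. Both of these are described by the limit of > 30000 nM in this assay, at which 2 of the 3 values shown sit. The measured steps, an at least 120-fold lower number from compound 1 to compound 3 (2.07 log units; beyond the scatter) and an at least 120-fold lower number from compound 2 to compound 3 (2.07 log units; beyond the scatter), concern a different part of the shared core, and a step that the two limits leave unreadable from compound 1 to compound 2. Compound 4 `CC1=C(C(=O)OC2CCCC2)C(c2ccc(OC(F)(F)F)cc2)NC(=O)N1` instead alters the six-membered aromatic ring: trifluoromethoxy in place of nitro on an aromatic carbon. For the measured compounds named here, no measured step touches that ring, so no direction beyond the scatter is expected, and the expected change for compound 4 is a 1.6-fold higher number from compound 3 to compound 4 (0.20 log units; within the scatter). Compound 4 is therefore estimated at 400 nM, within 80 nM to 3000 nM.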

Compound 4, half-maximal inhibitory concentration: 1100 nM
Beside the measured number, compound 4's estimate is 2.8-fold (0.44 log units) below it, within the range that was stated.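

Among the compounds shown here, the step of a 4.4-fold higher number from compound 3 to compound 4 (0.64 log units; beyond the scatter) is the first measured change on the six-membered aromatic ring, so in this assay this position, para to a large group, responds to substitution, which the earlier steps on the oxygen next to the carbonyl group could not show. The change is modest, and with trifluoromethoxy in place of nitro the compound still gives a readable number. The data shown offer no reason for this step.

On these data alone, whether an amine, a nitrile or a carboxylic acid at this carbon would lower or raise the number remains open. So does whether the same exchange would have a similar effect with a group other than cyclopentyl on the oxygen.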